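The source may report more compounds than this note shows. Statements on the series, on what has been measured and on what is new or still open speak of the compounds shown alone.

Measured in a functional assay on M21 cells (Homo sapiens) for antiproliferative activity, read by sulforhodamine B assay, with a stated time of 48 h; on this read-out higher numbers stand for weaker inhibition and lower numbers for stronger inhibition:
Compound 1 `CCCCc1ccc(NS(=O)(=O)c2ccc(N3CCNC3=O)cc2)cc1`: 450 nM
Compound 2 `CCCCCCCc1ccc(NS(=O)(=O)c2ccc(N3CCNC3=O)cc2)cc1`: > 1000 nM, a limit and not a number
Compound 3 `O=C1NCCN1c1ccc(S(=O)(=O)Nc2ccc(Cl)cc2)cc1`: 90 nM

Of the two true numbers in this assay, compound 3 holds the lower, 90 nM. Compound 4 `O=C1NCCN1c1ccc(S(=O)(=O)Nc2ccc(OC(F)F)cc2)cc1` carries difluoromethoxy in place of chloro on an aromatic carbon. Two measured steps change the same place, though neither involves difluoromethoxy: the modest 5.0-fold lower number from compound 1 to compound 3 (0.70 log units; beyond the scatter) and the large at least 11-fold lower number from compound 2 to compound 3 (1.04 log units; beyond the scatter). Both favour chloro over a chain, so losing chloro is expected to cost a little, but less than a chain does. The expected result is a 2.2-fold higher number from compound 3 to compound 4 (0.35 log units; beyond the scatter), a small step towards a higher number. Compound 4 is estimated at 200 nM, with an expected range from 70 nM to 600 nM.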

Compound 4, half-maximal inhibitory concentration: 410 nM
The estimate for compound 4 lay 2.1-fold (0.31 log units) below the measured number; the measured number falls inside the stated range.
By their numbers in this assay, from the lowest: compound 3; then compounds 4 and 1 (each within the scatter of the next). At a limit, above all of these: compound 2.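

In this assay, difluoromethoxy on this aromatic carbon, para to a large group, does not hold what chloro gives: a 4.6-fold higher number from compound 3 to compound 4 (0.66 log units; beyond the scatter). Compound 3 therefore keeps the lowest number, while the oxygen-linked group is not separated from butyl: a 1.1-fold lower number from compound 1 to compound 4 (0.04 log units; within the scatter). Against heptyl the result is an at least 2.4-fold lower number from compound 2 to compound 4 (0.38 log units; beyond the scatter), with compound 2 counting only as a limit and not a number: the limit of > 1000 nM in this assay, at which 1 of the 4 values shown sits.

As far as these compounds go, whether bromo, methoxy or trifluoromethoxy would come closer to chloro stays open. From the compounds shown here alone, compound 3 gives 90 nM, and whether any group at this place can go further down stays open too.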